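Moving the Ring Nitrogen on the Quinolinone Core

This account rests on a few compounds, and the source may have more. Where it says the series, first, only, none or still open, it means among the compounds named here.

Measured so far:
`O=C(COc1ccc2[nH]c(=O)c(-c3nccs3)c(CCc3ccccc3)c2c1)NC1(c2ccccc2)CC1` compound 1, 13 nM
`CC(C)(NC(=O)COc1ccc2[nH]c(=O)c(-c3ccccn3)c(CCc3ccccc3)c2c1)c1ccccc1` compound 2, 1370 nM

Of the compounds shown here, two have been measured in an assay on CHO-K1 cells for displacement of a labelled ligand from adenosine receptor A1 (Homo sapiens), with a stated time of 2 h; on this read-out lower numbers stand for stronger inhibition and higher numbers for weaker inhibition. Compound 1 gives 13 nM, and compound 2 gives 1370 nM. Compound 2 thus stands at the highest of the two numbers, and the gap to compound 1 lies well beyond the usual scatter; the two compounds differ in more than one place, so the data do not assign that gap to any single change.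

Compound 3 is `CC(C)(NC(=O)COc1ccc2[nH]c(=O)c(-c3cccnc3)c(CCc3ccccc3)c2c1)c1ccccc1`, not yet measured. It differs from compound 2 only in pyridin-3-yl in place of pyridin-2-yl on an aromatic carbon. Going by the values given here, no measured pair in this set shows the effect of moving the ring nitrogen in this way, so there is nothing to anchor the size or direction of the step. The estimate is therefore a cautious one: compound 3 is expected to sit near compound 2, with a step of a 1.5-fold higher number from compound 2 to compound 3 (0.16 log units; within the scatter) that may fall either way and need not exceed the scatter. For compound 3 the expected value is 2000 nM, within a range from 400 nM to 10000 nM.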

Compound 3, inhibition constant: 497 nM
For compound 3 the middle estimate is 4.0-fold (0.60 log units) above the measured one; the range from low to high includes it.
By their numbers in this assay, from the lowest: compound 1; then compound 3; then compound 2.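

Going by these compounds alone, the swap of pyridin-2-yl for pyridin-3-yl gives the first reading of a single change in this set: in this assay it produces a 2.8-fold lower number from compound 2 to compound 3 (0.44 log units; beyond the scatter), so the position ortho to a phenethyl group responds to where the ring nitrogen sits, although the effect is modest. Both groups have the same heavy atoms, and the whole molecule keeps the same atoms, so the step comes from a change in how those atoms are joined and not from any change in composition. No available measurement accounts for the step, and so the data give no reason for it.

From the compounds shown here alone, whether the trend continues with pyridin-4-yl, or whether a plain phenyl ring at this position would give a lower or a higher number than either pyridine, remains open. Compound 2 differs from compound 1 in more than one place, so the compounds shown also leave unsettled how much of the value of compound 1, which is 13 nM, belongs to the group on this aromatic carbon and how much to the group on the amide nitrogen.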